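Carboxy for trifluoromethyl on the anilide ring of the shared core

The compounds below may be only part of what the source reports. "The series", "measured", "known", "first", "only" and "open" are said of these compounds alone.

Of the compounds shown here, two have been measured in a functional assay on the whole organism for inhibition, with Rattus norvegicus as the target, read by paw edema, with stated times of 30 min and 4 h, at a dose of 0.28 mmol/kg by the oral route; on this read-out higher numbers stand for more inhibition at the one dose given (going by the name of the read-out) and lower numbers for less inhibition. Compound 1 `COc1ccc(-n2nc(C(=O)Nc3ccc(C)cc3)nc2-c2cc(OC)c(OC)c(OC)c2)cc1` carries methyl on the anilide ring and gives 58%. Compound 2 `COc1ccc(-n2nc(C(=O)Nc3ccc(C(F)(F)F)cc3)nc2-c2cc(OC)c(OC)c(OC)c2)cc1` carries trifluoromethyl in the same place and gives 56%. The step of a number 2 percentage points lower from compound 1 to compound 2 (within the scatter) shows that these two numbers are not separable in this assay. Compound 2 is therefore the starting point of the next step, and its number is indistinguishable from that of compound 1.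

Compound 3 `COc1ccc(-n2nc(C(=O)Nc3ccc(C(=O)O)cc3)nc2-c2cc(OC)c(OC)c(OC)c2)cc1` has not been measured. Its difference from compound 2 is carboxy in place of trifluoromethyl on an aromatic carbon. Among the measured compounds shown here, the only measured step, a number 2 percentage points lower from compound 1 to compound 2 (within the scatter), swaps two groups at this same position and moves the number nowhere beyond the scatter. For the measured compounds named here, that step does not involve carboxy, so the step from compound 2 to compound 3 is not covered by any measured pair; the carboxy change is new in this set, and the expectation rests only on the number having stayed level across the one change made at this place so far. The estimate for compound 3 is 54%, expected range 36% to 72%, which means an expected step of a number 2 percentage points lower from compound 2 to compound 3 (within the scatter), no direction beyond the scatter being anticipated.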

Compound 3, a percentage reported as inhibition, in the whole organism at one dose (the size of the read-out at that dose, not a potency): 69%
Estimate against measurement, compound 3: 15 percentage points below; measured number inside the range.
By their numbers in this assay, from the lowest: compounds 2 and 1 (each within the scatter of the next); then compound 3.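

In this assay, the position on the anilide ring looked indifferent while only methyl and trifluoromethyl had stood there, but it does respond to the group it carries: carboxy gives a number 13 percentage points higher from compound 2 to compound 3 (beyond the scatter), and likewise a number 11 percentage points higher from compound 1 to compound 3 (beyond the scatter). Among the compounds shown here, both steps are modest and point the same way, so carboxy is the one group of the three that separates from the others at this place, and it does so against either of them as the reference. Nothing available here accounts for the difference between carboxy and the other two groups.

Going by these compounds, whether the higher number belongs to carboxy itself or would also come with another group at this place, such as an amine, a hydroxy group or the methyl ester of the same acid, remains open. Also open, on these data alone, is whether carboxy would act in the same way elsewhere on this ring or with a longer chain between it and the ring, and each reading here comes from a single dose, so how the numbers would compare at other doses is unknown too.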